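Bromine on the Benzyl Ring of Compound 1

The compounds below may be only part of what the source reports. "The series", "measured", "known", "first", "only" and "open" are said of these compounds alone.

Compound 1 `CCN(Cc1ccccc1)c1cccc(C(=O)N2CCc3ccc(OS(N)(=O)=O)cc3C2)c1` gives 17.3% in an assay on HEK293 cells for inhibition of Steryl-sulfatase (Homo sapiens), tested at 0.1 uM (a lower number here means a weaker effect, a higher number a stronger effect of the compound at the concentration tested), the lowest of the two numbers at hand. Within the data shown here, its only measured neighbour is compound 2 `NS(=O)(=O)Oc1ccc2c(c1)CN(C(=O)c1cccc(N(Cc3ccccc3)Cc3ccco3)c1)CC2`, which in this assay gives 27.5%; the single measured step, a number 10.2 percentage points higher from compound 1 to compound 2 (beyond the scatter), is modest and concerns the group on the saturated chain carbon bound to the aromatic nitrogen. Compound 3 `CCN(Cc1ccc(Br)cc1)c1cccc(C(=O)N2CCc3ccc(OS(N)(=O)=O)cc3C2)c1` differs from compound 1 by bromo in place of hydrogen on an aromatic carbon. Among the measured compounds shown here, no measured step touches the phenyl to 4-bromophenyl change, so the step from compound 1 to compound 2 offers only a hint that changes on the amine substituents shift the read-out by modest amounts. On that basis compound 3 is expected to show a small rise, a number 4.7 percentage points higher from compound 1 to compound 3 (within the scatter). Compound 3 is therefore estimated to give 22% in this assay, with a range from 10% to 38%.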

Compound 3, a percentage reported as inhibition, at one concentration (the size of the read-out at that concentration, not a potency): 24.2%
Beside the measured number, compound 3's estimate is 2.2 percentage points below it, and the stated range covers the measured number.
By their numbers in this assay, from the lowest: compounds 1, 3 and 2 (each within the scatter of the next, the first and the last beyond it).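

Among these compounds, compound 3 is the first change on the benzyl ring itself, since the earlier step concerned the other substituent on the amine nitrogen. In this assay, 4-bromobenzyl in place of benzyl, with the bromo para to a large group, gives a number 6.9 percentage points higher from compound 1 to compound 3 (within the scatter), so this single heavy atom at this position does not separate the two compounds beyond the usual scatter. Nothing measured on these compounds speaks to why the read-out behaves this way.

The compounds shown leave open whether a different group at this ring position, such as a methoxy group, a nitrile or a carboxylic acid, would move the read-out beyond the scatter. They also leave open how bromo at this position would behave with furan-2-ylmethyl in place of the ethyl group.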